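Dicyclohexylguanidines: hydroxy on the double-bonded nitrogen removed

The source may report more compounds than this note shows. Statements on the series, on what has been measured and on what is new or still open speak of the compounds shown alone.

Of the compounds shown here, three have been measured in an assay on membranes from brain (Cavia porcellus) for binding affinity to Sigma non-opioid intracellular receptor 1 (Homo sapiens); a higher number here means a weaker inhibitor, a lower number a stronger inhibitor. Compound 1 `N=C(Nc1ccccc1I)NC1CC2CCC1C2` gives 4 nM. Compound 2 `CC(C)(C)c1ccccc1NC(=N)Nc1ccccc1C(C)(C)C` gives 356 nM. Compound 3 `ON=C(NC1CCCCC1)NC1CCCCC1` gives 271 nM, the second highest of the three numbers; its nearest neighbour is compound 2, whose number is within the scatter of that of compound 3, and its furthest is compound 1, whose number lies far lower, beyond the scatter.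

Compound 4 `N=C(NC1CCCCC1)NC1CCCCC1` has not yet been measured. It differs from compound 3 in one place: hydrogen in place of hydroxy on a double-bonded nitrogen. Among the measured compounds shown here, no pair of measured compounds differing in a single place is available, so the size of this step rests on expectation alone. In this assay, for the measured compounds named here, the step from compound 3 to compound 4 is expected to go toward a lower number, beyond the scatter, as the one measured compound that carries no hydroxy on the double-bonded nitrogen, compound 1, gives 4 nM, although compound 1 also differs from compound 4 in both groups on the guanidine. The expected step is a 9.0-fold lower number from compound 3 to compound 4 (0.96 log units; beyond the scatter). For compound 4 in this assay the estimate is 30 nM, with a range from 8 nM to 110 nM.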

Compound 4, half-maximal inhibitory concentration: 71 nM
Compound 4: the middle estimate sits 2.4-fold (0.37 log units) below what was measured; the measured number falls inside the stated range.
By their numbers in this assay, from the lowest: compound 1; then compound 4; then compounds 3 and 2 (each within the scatter of the next).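

This change gives the series its first comparison that differs in a single place. In this assay, among the compounds shown here, the step is modest but beyond the scatter (a 3.8-fold lower number from compound 3 to compound 4 (0.58 log units; beyond the scatter)), so the substituent on the double-bonded nitrogen does affect the number even with both groups on the guanidine held constant, and the hydroxy compound is the one with the higher number. Nothing at hand accounts for the direction or size of this step.

On these data alone, it remains open whether this step is specific to hydroxy, as a methoxy, amino or methyl group on the same nitrogen would be needed to show whether the number follows the loss of hydroxy or changes with any group placed there. It is also open whether a step of this size carries over to other groups on the guanidine, since neither compound 1 nor compound 2 has a partner among the compounds shown that differs from it only on the double-bonded nitrogen.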